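This account rests on a few compounds, and the source may have more. Where it says the series, first, only, none or still open, it means among the compounds named here.

In a functional assay (trachea) with Cavia porcellus as the target (on this read-out lower numbers stand for stronger inhibition and higher numbers for weaker inhibition), compound 1 `O=c1c2ccccc2c(-c2cccnc2)nn1CCSc1nccs1` gives 10500 nM. In this assay, compound 2 `NCCn1nc(-c2cccnc2)c2ccccc2c1=O` gives > 100000 nM, and this value is only a limit of the assay, not a number. Compound 2 therefore offers no exact starting point. Among the compounds with values here, the one measured step that bears on what comes next is an at least 9.5-fold higher number from compound 1 to compound 2 (0.97 log units; beyond the scatter), in which amino takes the place of (1,3-thiazol-2-yl)sulfanyl on the chain.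

Compound 3 `O=c1c2ccccc2c(-c2cccnc2)nn1CCNS(=O)(=O)c1ccccc1` has phenylsulfonyl in place of hydrogen on an amine nitrogen of compound 2 (phenylsulfonyl in place of hydrogen on an amine nitrogen). This brings an aromatic ring back to the chain, and compound 1, at 10500 nM, shows that a chain bearing a ring can give a measurable number. A move towards stronger inhibition is therefore expected, though compound 3 may not fully match compound 1. The expected change is an at least 5.0-fold lower number from compound 2 to compound 3 (0.69 log units; beyond the scatter). For compound 3 the estimated value is 20000 nM, with an expected range of 4000 nM to 90000 nM.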

Compound 3, half-maximal inhibitory concentration: 26300 nM
The estimate for compound 3 lay 1.3-fold (0.12 log units) below the measured number; measured number inside the range.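

In this assay, phenylsulfonyl in place of hydrogen on the amine nitrogen gives an at least 3.8-fold lower number from compound 2 to compound 3 (0.58 log units; beyond the scatter). This shows that the amine nitrogen can carry a substituent and still return a measurable number, here with a six-membered aromatic ring of carbon only in the new group. Compound 2 stands at a limit of the assay, not a number, so this step gives only a minimum size and the true change may be larger: the limit of > 100000 nM in this assay, at which 1 of the 3 values shown sits.

The compounds shown leave open whether the sulfonyl link or the aromatic ring accounts for this step, which methylsulfonyl or benzoyl on the same nitrogen would help to separate. They also leave open how a methoxy group on the phenyl ring or a longer chain would shift the number.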